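Swapping Chloro for Bromo on a Shared Core

The source may hold more compounds than are shown below. What is called first, only, known or untested is meant among the compounds shown, and "the series" means these compounds.

Measured compounds:
- compound 1, `O=C(Nc1cccc(Cl)c1)C(Cl)Cl`, gives 14800 nM
- compound 2, `O=C(Nc1cccc(Br)c1)C(Cl)Cl`, gives 7800 nM
- compound 3, `O=C(Nc1ccc(Cl)cc1)C(Cl)Cl`, gives 20400 nM

All three values come from a functional assay on A549 cells (Homo sapiens) for antiproliferative activity, read by MTT assay, with a stated time of 72 h; on this read-out lower numbers stand for stronger inhibition and higher numbers for weaker inhibition. Compound 1 and compound 2 differ in one place: bromo in place of chloro on an aromatic carbon. That change gave a 1.9-fold lower number from compound 1 to compound 2 (0.28 log units; within the scatter), so within the spread that repeated measurements of this kind usually show. Compound 3 is built from the same atoms as compound 1, joined differently; the difference between the two cores is not broken down here. In this assay compound 3 gives 20400 nM, while compound 1 gives 14800 nM, and these two numbers lie within the usual scatter of each other.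

Compound 4, `O=C(Nc1ccc(Br)cc1)C(Cl)Cl`, has not yet been measured. It differs from compound 3 as follows: bromo in place of chloro on an aromatic carbon. Within the data shown here, this is the same kind of change as the one from compound 1 to compound 2, but not the same: in the earlier pair the bromo sits meta to a group of 6 heavy atoms, in the new pair it sits para to a group of 6 heavy atoms. Because the earlier change gave only a 1.9-fold lower number from compound 1 to compound 2 (0.28 log units; within the scatter), a step of similar size is expected here, and the expected step from compound 3 to compound 4 in this assay is a 1.9-fold lower number from compound 3 to compound 4 (0.27 log units; within the scatter). For compound 4 the estimated value in this assay is 11000 nM, with a likely range from 5000 nM to 25000 nM.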

Compound 4, half-maximal inhibitory concentration: 13700 nM
Beside the measured number, compound 4's estimate is 1.2-fold (0.10 log units) below it; measured number inside the range.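

In this assay, putting bromo in place of chloro on the aromatic carbon of compound 3 gives a 1.5-fold lower number from compound 3 to compound 4 (0.17 log units; within the scatter), a step small enough that it could come from ordinary repeat-to-repeat variation alone. The same swap has now been read on two cores, and the two steps agree, so nothing here suggests that the core changes what this swap does: the same change on two cores in this assay, a 1.9-fold lower number (0.28 log units; within the scatter) from compound 1 to compound 2 and a 1.5-fold lower number (0.17 log units; within the scatter) from compound 3 to compound 4, 1.3-fold (0.11 log units) apart, within the scatter of two such steps. This agreement is modest evidence, however: each step lies within the scatter, so neither pair shows on its own that bromo truly differs from chloro, and two cores in one cell assay cannot establish that the swap will behave in the same way on a third core.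

The compounds shown carry only chloro or bromo on the aromatic ring, so it remains open whether a fluoro or iodo group, or a quite different group such as an amine or a carboxylic acid, would move the number beyond the scatter. Also open is what happens when the two chlorines on the other end of the molecule are replaced, since they stay the same in all the compounds shown.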